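Compound 3 to compound 4: a change of aryl group

The compounds below may be only part of what the source reports. "The series", "measured", "known", "first", "only" and "open" are said of these compounds alone.

In a functional assay on HCT-116 cells (Homo sapiens) for antiproliferative activity, read by sulforhodamine B assay, with a stated time of 48 h (on this read-out higher numbers stand for weaker inhibition and lower numbers for stronger inhibition), compound 1 `COc1cc(OC)c(C(=O)/C=C/c2ccc(OC)c(OC)c2)c(OCC=C(C)C)c1` gives 5700 nM, compound 2 `COc1ccc(/C=C/C(=O)c2c(OC)cc(OC)cc2OCC=C(C)C)cc1` gives 7600 nM and compound 3 `COc1cc(OC)c(C(=O)/C=C/c2ccc(F)cc2)c(OCC=C(C)C)c1` gives 3200 nM. Compound 3 sits at the low end of these three numbers, but it is clearly separated only from compound 2.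

Compound 4 `COc1cc(OC)c(C(=O)/C=C/c2cccc(Cl)c2Cl)c(OCC=C(C)C)c1` differs from compound 3 in one place: 2,3-dichlorophenyl in place of 4-fluorophenyl on a double-bonded chain carbon bound to a double-bonded chain carbon.

For the measured compounds named here, two measured steps bear on this change. Going by the values given here, the first replaces the whole group at the same place and gives a 1.8-fold lower number from compound 1 to compound 3 (0.25 log units; within the scatter). The second gives a 2.4-fold lower number from compound 2 to compound 3 (0.38 log units; beyond the scatter), a modest step in which fluoro replaces methoxy on that same ring. Neither step is large, and only the second passes the scatter. Among the compounds with values here, no measured compound carries chlorine, so the data give no direct reading on the 2,3-dichlorophenyl group and do not settle a direction. No shift beyond the scatter is therefore expected, although the range has to stay wide.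

The expected result is a 1.1-fold higher number from compound 3 to compound 4 (0.04 log units; within the scatter), which would not be a real separation. Compound 4 is estimated at 3500 nM, with an expected range of 1400 nM to 8500 nM.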

Compound 4, half-maximal inhibitory concentration: 1900 nM
Estimate against measurement, compound 4: 1.8-fold (0.27 log units) above, within the range that was stated.
By their numbers in this assay, from the lowest: compounds 4, 3, 1 and 2 (each within the scatter of the next, the first and the last beyond it).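

In this assay, 2,3-dichlorophenyl and 4-fluorophenyl are not separated at this place on a double-bonded chain carbon bound to a double-bonded chain carbon (a 1.7-fold lower number from compound 3 to compound 4 (0.23 log units; within the scatter)). Compound 4 is nevertheless separated from both methoxy-bearing compounds (a 3.0-fold lower number from compound 1 to compound 4 (0.48 log units; beyond the scatter); a 4.0-fold lower number from compound 2 to compound 4 (0.60 log units; beyond the scatter)), whereas compound 3 was separated only from compound 2, so the series now shows that chlorine is accepted here and that the methoxy-bearing rings can be passed by a margin beyond the scatter on both steps, though each of these steps remains modest. No measurement in hand bears on the reason for the size of these steps.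

With both chlorines introduced together, the series does not tell what each contributes alone, and 2-chlorophenyl and 3-chlorophenyl would separate the two. Also open, on these data alone, is how this place responds to a group of another kind, such as an amine or a carboxylic acid on the ring, and whether the 2,3-dichlorophenyl result carries over when the other parts of the shared core change.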